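Removing the methoxy from compound 2: what to expect

A few compounds are considered here, and "the series" means these few. Any claim that something is new, unique, unknown or untested is made for them only; others in the source may bear on it.

Measured compounds:
compound 1, `CN(C)CCC(OC(=O)c1cc2ccccc2n1C)c1ccc(Cl)cc1`, 73%
compound 2, `COc1ccc(C(=O)NC(CCN(C)C)c2ccc(Cl)cc2)cc1`, 162%

Of the compounds shown here, two have been measured in an assay on NIH3T3 cells with Urotensin-2 receptor (Homo sapiens) as the target; a higher number here means a larger maximal response, a lower number a smaller maximal response. Compound 1, `CN(C)CCC(OC(=O)c1cc2ccccc2n1C)c1ccc(Cl)cc1`, gives 73% in this assay. Compound 2, `COc1ccc(C(=O)NC(CCN(C)C)c2ccc(Cl)cc2)cc1`, gives 162% in this assay, which is the higher of the two numbers and lies beyond the scatter above compound 1. Within the data shown here, no step between compounds that differ in a single place has been measured, so the two values only show that compound 2 reaches the larger maximal response.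

Compound 3, `CN(C)CCC(NC(=O)c1ccccc1)c1ccc(Cl)cc1`, has not yet been measured. It differs from compound 2 in one place: hydrogen in place of methoxy on an aromatic carbon, on an aromatic carbon of a six-membered aromatic ring of carbon only, para to a large group. Among the measured compounds shown here, nothing measured so far tells how this assay responds to such a change, so the expectation rests on the high value of compound 2 alone. A step of moderate size downward is expected, as a number 42 percentage points lower from compound 2 to compound 3 (beyond the scatter), though a step within the scatter cannot be ruled out. For compound 3 the estimated value in this assay is 120%, within a range from 60% to 180%.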

Compound 3, largest response reached (reported as efficacy), in percent of the reference or control that the assay uses: 158%
Compound 3: the middle estimate sits 38 percentage points below what was measured; the measured number falls inside the stated range.
By their numbers in this assay, from the lowest: compound 1; then compounds 3 and 2 (each within the scatter of the next).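

In this assay, exchanging the methoxy for hydrogen on this aromatic carbon, para to a large group, gives a number 4 percentage points lower from compound 2 to compound 3 (within the scatter). Among these compounds, this is the first single-place comparison, and it shows that the change from 4-methoxyphenyl to phenyl does not separate the two compounds beyond the usual scatter. The large maximal response seen with compound 2 therefore does not depend on the methoxy, since compound 3, which carries only hydrogen at this place, gives 158% in this assay.

As far as these compounds go, whether this insensitivity extends to other groups on the same aromatic carbon remains open, for example a hydroxyl, an amine, a carboxylic acid or a longer chain such as ethoxy, any of which might shift the response beyond the scatter. From the compounds shown here alone, it also remains open whether the same exchange of methoxy for hydrogen would read alike on another carbon of this ring, since only this one place has been compared so far. Nothing at hand speaks to why the step is as small as it is.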